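This account rests on a few compounds, and the source may have more. Where it says the series, first, only, none or still open, it means among the compounds named here.

Compound 1 `N#Cc1ccccc1-c1cnc(C(=O)CCCCCCc2ccccc2)o1` gives 130 nM in an assay (Rattus norvegicus) for inhibition of Fatty-acid amide hydrolase 1 (Homo sapiens); a lower number here means a stronger inhibitor, a higher number a weaker inhibitor; compound 2 `O=C(CCCCCCc1ccccc1)c1ncc(-c2cccc(O)c2)o1` gives 50 nM; compound 3 `COc1ccnc(-c2cnc(C(=O)CCCCCCc3ccccc3)o2)c1` gives 0.8 nM. Compound 3 stands lowest of the three, ahead of compound 2 by a 63-fold lower number from compound 2 to compound 3 (1.80 log units; beyond the scatter) and ahead of compound 1 by a 160-fold lower number from compound 1 to compound 3 (2.21 log units; beyond the scatter). Compound 4 `CN(C)C(=O)c1cnc(C(=O)CCCCCCc2ccccc2)o1` differs from it by dimethylcarbamoyl in place of 4-methoxypyridin-2-yl on an aromatic carbon. Among the compounds with values here, no measured step exchanges an aromatic ring for an open-chain group; the steps of a 2.6-fold lower number from compound 1 to compound 2 (0.41 log units; beyond the scatter) and a 160-fold lower number from compound 1 to compound 3 (2.21 log units; beyond the scatter) show only how far the number moves when the group on this carbon changes, and that compound 3 owes its position to the 4-methoxypyridin-2-yl. The step of a 38-fold higher number from compound 3 to compound 4 (1.57 log units; beyond the scatter) is therefore expected to be large and upward. Compound 4 is estimated at 30 nM, within 5 nM to 200 nM.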

Compound 4, inhibition constant: 2 nM
Beside the measured number, compound 4's estimate is 15-fold (1.18 log units) above it, outside the stated range (below it).
By their numbers in this assay, from the lowest: compound 3; then compound 4; then compound 2; then compound 1.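

At this carbon next to the ring oxygen, an aromatic ring is not needed for a low number: the dimethylcarbamoyl, which has no ring, gives only a 2.5-fold higher number from compound 3 to compound 4 (0.40 log units; beyond the scatter), a modest step though still beyond the scatter. The same group outdoes both the 3-hydroxyphenyl and the 2-cyanophenyl, with a 25-fold lower number from compound 2 to compound 4 (1.40 log units; beyond the scatter) and a 65-fold lower number from compound 1 to compound 4 (1.81 log units; beyond the scatter). Nothing available explains why this open-chain group comes so close to the 4-methoxypyridin-2-yl. From the compounds shown here alone, whether the number depends on the carbonyl or on the two methyl groups remains open. A primary carboxamide, a carboxylic acid or a methyl ester at this carbon would help separate the two.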